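Extending the Chain on the Ring Nitrogen of Compound 1

The compounds below may be only part of what the source reports. "The series", "measured", "known", "first", "only" and "open" are said of these compounds alone.

Of the compounds shown here, three have so far been measured in an assay on HEK293 cells for positive allosteric modulation of metabotropic glutamate receptor 2 (Rattus norvegicus), read by thallium flux; a lower number here means a smaller maximal response, a higher number a larger maximal response. Compound 1 `Cn1sc2cc(OCc3cccc(-c4ccc(Cl)c(C(=O)O)c4)c3)ccc2c1=O` gives 74.7% in this assay. Compound 2 `COc1ccc(-c2cccc(COc3ccc4c(c3)CN(C3CCCC3)C4=O)c2)cc1C(=O)O` gives 78%, and compound 3 `O=C(O)c1cc(-c2cccc(COc3ccc4c(=O)n(C5CCCC5)sc4c3)c2)ccc1F` gives 83.4%. On these numbers compound 1 sits at the low end, but the gap to compound 2 and the gap to compound 3 both lie within the usual scatter of such measurements, so the three cannot be told apart on the strength of these values.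

Compound 4 `CC(C)CCn1sc2cc(OCc3cccc(-c4ccc(Cl)c(C(=O)O)c4)c3)ccc2c1=O` has not yet been measured. It differs from compound 1 in one place: isobutyl in place of hydrogen on a saturated chain carbon bound to an aromatic nitrogen. Cut one bond further out, the same change reads as methyl to isopentyl; the carboxylic acid, the chlorine and the rest of the shared core are unchanged.

For the measured compounds named here, no pair of measured compounds differs in just one place, so there is no measured step to lean on. The change adds only a small chain without ring, donor or acceptor, and the three measured values cluster closely. The step from compound 1 to compound 4 is therefore expected to stay within the scatter, as a number 2.3 percentage points higher from compound 1 to compound 4 (within the scatter). For compound 4 a value of 77% is estimated, with a likely range from 60% to 94%.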

Compound 4, largest response reached (reported as percent of maximum), in percent of the reference or control that the assay uses: 67.3%
Compound 4: the middle estimate sits 9.7 percentage points above what was measured; measured number inside the range.
By their numbers in this assay, from the lowest: compounds 4, 1, 2 and 3 (each within the scatter of the next, the first and the last beyond it).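

For the compounds shown here, this is the first measured comparison in which only one place changes. In this assay the step reads a number 7.4 percentage points lower from compound 1 to compound 4 (within the scatter) and stays within the scatter, so the maximal response does not distinguish the methyl of compound 1 from the isopentyl of compound 4. For this position, that means a chain carrying isobutyl in place of hydrogen, on a saturated chain carbon bound to an aromatic nitrogen, still leaves a maximal response that cannot be told apart from the smaller group's, though this single pair describes only these two groups and no wider trend along a series of chains. No measurement shown here offers a reason for this result, either for the small size of the step or for its direction.

Compound 3 holds a cyclopentyl group at this nitrogen but also differs elsewhere, so the effect of a ring here stays unresolved on the compounds shown. As far as these compounds go, it also remains open whether an amine, a hydroxyl group or a carboxylic acid on this chain would leave the maximal response just as unchanged as the isobutyl group did.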